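The source may report more compounds than this note shows. Statements on the series, on what has been measured and on what is new or still open speak of the compounds shown alone.

Measured in an in vitro assay on CHO cells for displacement of a labelled ligand from Bombesin receptor subtype-3 (Homo sapiens), read by scintillation counting, with a stated time of 2 h; on this read-out lower numbers stand for stronger inhibition and higher numbers for weaker inhibition:

compound 1 `CCC(C)(C)Cc1c[nH]c(CCc2ccc(-c3cccc(N)n3)cc2)n1`: 7.3 nM
compound 2 `CCC(C)(C)Cc1c[nH]c(CCc2ccc(N3CCCCC3)cc2)n1`: 28 nM
compound 3 `CCC(C)(C)Cc1c[nH]c(CCc2ccc(-n3cccn3)cc2)n1`: 33 nM

Compound 1 holds the lowest number of the three; compound 2 is nearest with a 3.8-fold higher number from compound 1 to compound 2 (0.58 log units; beyond the scatter) and compound 3 furthest with a 4.5-fold higher number from compound 1 to compound 3 (0.66 log units; beyond the scatter). The gap from compound 2 to compound 3 is a 1.2-fold higher number from compound 2 to compound 3 (0.07 log units; within the scatter).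

Compound 4 `CCC(C)(C)Cc1c[nH]c(CCc2ccc(-c3ccns3)cc2)n1` is not yet measured. Its change from compound 1: 1,2-thiazol-5-yl in place of 6-aminopyridin-2-yl on an aromatic carbon. Both measured steps from compound 1, to compound 2 and to compound 3, replace the 6-aminopyridin-2-yl group with a ring lacking the amino group and each gives a modest loss beyond the scatter. The same direction and a similar size are expected here in this assay.

Compound 4 is therefore estimated at 25 nM, with a range of 8 nM to 80 nM. The expected step is a 3.4-fold higher number from compound 1 to compound 4 (0.53 log units; beyond the scatter).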

Compound 4, half-maximal inhibitory concentration: 11 nM
Compound 4: middle estimate off by 2.3-fold (0.36 log units), on the high side; measured number inside the range.
By their numbers in this assay, from the lowest: compounds 1 and 4 (each within the scatter of the next); then compounds 2 and 3 (each within the scatter of the next).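

In this assay, the amino group of 6-aminopyridin-2-yl is not needed to hold the number at this position: 1,2-thiazol-5-yl, with no hydrogen-bond donor, gives a 1.5-fold higher number from compound 1 to compound 4 (0.18 log units; within the scatter). Loss of the amino group alone therefore does not account for the weaker rings, as 1,2-thiazol-5-yl gives a 3.0-fold lower number from compound 3 to compound 4 (0.48 log units; beyond the scatter) and a 2.5-fold lower number from compound 2 to compound 4 (0.41 log units; beyond the scatter). No supporting data explain this difference between the rings.

Still open, on these data alone, is how a 1,2-thiazol-5-yl carrying an amine or a methyl group would read, and whether an unsubstituted phenyl ring at this place would match compound 4.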